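From 4-fluorophenyl to 3-chlorophenyl at the assay limit

This account rests on a few compounds, and the source may have more. Where it says the series, first, only, none or still open, it means among the compounds named here.

Measured so far in an ADME assay on GES1 cells (Homo sapiens) for cytotoxicity, read by MTT assay, with a stated time of 24 h (on this read-out lower numbers stand for higher toxicity in this test and higher numbers for lower toxicity in this test), and in no other test
- compound 1 (`Cc1ccc(-n2cc(-c3ccc(NS(=O)(=O)c4c[nH]c(=O)[nH]c4=O)cc3)nn2)cc1`) gives "not toxic" (no number reported) with no number reported
- compound 2 (`O=c1[nH]cc(S(=O)(=O)Nc2ccc(-c3cn(-c4ccccc4F)nn3)cc2)c(=O)[nH]1`) gives > 100000 nM as a limit
- compound 3 (`O=c1[nH]cc(S(=O)(=O)Nc2ccc(-c3cn(-c4ccc(F)cc4)nn3)cc2)c(=O)[nH]1`) gives > 100000 nM as a limit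

Compound 3 has no number to place it, only its limit of > 100000 nM in this assay and nothing finer. Among the compounds with values here, the series so far shows the limit of > 100000 nM in this assay, at which 2 of the 3 values shown sit, and compound 1 adds no number to that.

Compound 4 (`O=c1[nH]cc(S(=O)(=O)Nc2ccc(-c3cn(-c4cccc(Cl)c4)nn3)cc2)c(=O)[nH]1`) carries 3-chlorophenyl in place of 4-fluorophenyl on an aromatic nitrogen, counted as 3-chlorophenyl in place of 4-fluorophenyl on an aromatic nitrogen and otherwise shares the core of compound 3.

Within the data shown here, the one measured step that bears on this place is a step that the two limits leave unreadable from compound 2 to compound 3 and it offers no size to carry over. No direction can be read from it, so no change beyond the usual scatter is expected. The expected change is a step that the limit leaves unreadable from compound 3 to compound 4 and it remains a rough estimate. Expected for compound 4 is a value of 120000 nM within a range of 50000 nM to 300000 nM and most probably only a limit will be reported.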

Compound 4, half-maximal cytotoxic concentration: 7570 nM
Estimate against measurement, compound 4: 16-fold (1.20 log units) above, outside the stated range (below it).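

Exchanging the aryl group on the aromatic nitrogen can move the read-out in this assay, which the two fluorophenyl compounds could not show: the change to 3-chlorophenyl gives an at least 13-fold lower number from compound 3 to compound 4 (1.12 log units; beyond the scatter), and the comparison with the 2-fluorophenyl compound gives an at least 13-fold lower number from compound 2 to compound 4 (1.12 log units; beyond the scatter). Both steps point towards higher toxicity in this test, and both sizes are lower bounds. Compound 4 is the only compound shown with a value that lies off the limit: the limit of > 100000 nM in this assay, at which 2 of the 4 values shown sit.

The 3-chlorophenyl group differs from both fluorophenyl groups in its halogen and in where that halogen sits, so the compounds shown cannot say which of the two matters; 3-fluorophenyl and 4-chlorophenyl would separate them. Going by these compounds, whether an amine or a carboxylic acid on the same phenyl ring would also lower the number remains open.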